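Thiazole in place of pyrimidine: expected effect on half-life

The source may hold more compounds than are shown below. What is called first, only, known or untested is meant among the compounds shown, and "the series" means these compounds.

Of the compounds shown here, two have been measured in an ADME assay on the whole organism (Mus musculus, strain BALB/c) for metabolic stability, read by LC-MS, with a stated time of 24 h, at a dose of 1 mg/kg by the intravenous route; a higher number here means that the compound lasts longer, a lower number that the compound disappears faster. Compound 2 `O=S(=O)(Nc1ncccn1)c1ccc2c(c1)OCC[C@@H]2c1ccc(C(F)(F)F)cc1-c1ccc(F)nc1` sits at the top of those two numbers with 3.2 h, while compound 1 `Cn1nccc1-c1cc(C(F)(F)F)ccc1[C@H]1CCc2cc(S(=O)(=O)Nc3ncccn3)ccc21` gives 2.8 h; the gap between them lies within the scatter, so the two cannot be told apart. Compound 3 `O=S(=O)(Nc1nccs1)c1ccc2c(c1)OCC[C@@H]2c1ccc(C(F)(F)F)cc1-c1ccc(F)nc1` differs from compound 2 only in the group on the sulfonamide nitrogen: 1,3-thiazol-2-yl in place of pyrimidin-2-yl on a sulfonamide nitrogen. Among the measured compounds shown here, no measured pair shows this change, so its effect is unknown. The expected step of no change at the digits printed from compound 2 to compound 3 (within the scatter) is small, with no direction beyond the scatter. Compound 3 is estimated at 3.2 h, between 1.6 h and 6.4 h in this assay.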

Compound 3, half-life: 2.8 h
Compound 3: the middle estimate sits 1.1-fold (0.06 log units) above what was measured, within the range that was stated.
By their numbers in this assay, from the lowest: compounds 1, 3 and 2 (each within the scatter of the next).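

In this assay, placing 1,3-thiazol-2-yl instead of pyrimidin-2-yl on the sulfonamide nitrogen gives a 1.1-fold lower number from compound 2 to compound 3 (0.06 log units; within the scatter). Among the compounds shown here, this is the first measured pair at this position, and it shows that a five-membered aromatic ring can take the place of the six-membered one with no difference in half-life that can be read. Nothing available bears on the cause of this result. Still open, on these data alone, is whether a methyl or acetyl group on that nitrogen would shift the half-life beyond the scatter. As far as these compounds go, the same swap on the core of compound 1 also remains open.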